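Closing an amide chain into an azetidine ring

A few compounds are considered here, and "the series" means these few. Any claim that something is new, unique, unknown or untested is made for them only; others in the source may bear on it.

Measured so far:
compound 1 `O=C(/C=C1\CCc2ccc(F)cc21)NCC1CC1` gives 50% in a functional assay on the whole organism with Mus musculus as the target, at a dose of 100 mg/kg by the intraperitoneal route; a lower number here means less inhibition, a higher number more inhibition at the dose given (going by the name of the read-out)
compound 2 `O=C(/C=C1\CCc2ccc(F)cc21)NCCO` gives 50% in this assay
compound 3 `CCN(C)C(=O)/C=C1\CCc2ccc(F)cc21` gives 100% in this assay

Compound 3 stands highest of the three, and its lead over each of the others is beyond the scatter. Both measured steps that reach it, a number 50 percentage points higher from compound 1 to compound 3 (beyond the scatter) and a number 50 percentage points higher from compound 2 to compound 3 (beyond the scatter), swap an amide carrying a hydrogen for one without. Compound 4 `O=C(/C=C1\CCc2ccc(F)cc21)N1CCC1` keeps that pattern: azetidin-1-yl in place of ethyl(methyl)amino on a carbonyl carbon. Among the compounds with values here, the change counts no donor or acceptor on either side, so neither measured step argues for a shift; no step of this kind has been measured, and within that uncertainty the expected result is a number 10 percentage points lower from compound 3 to compound 4 (within the scatter). Compound 4 is therefore expected to give 90%, within 65% to 100%.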

Compound 4, a percentage reported as inhibition, in the whole organism at one dose (the size of the read-out at that dose, not a potency): 33%
The estimate for compound 4 lay 57 percentage points above the measured number; measured number below the stated range.
By their numbers in this assay, from the lowest: compound 4; then compounds 1 and 2 (each within the scatter of the next); then compound 3.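

Removing the amide hydrogen is not enough on its own to give a high number. Compound 4 has no such hydrogen either, yet on the carbonyl carbon, azetidin-1-yl in place of ethyl(methyl)amino gives a number 67 percentage points lower from compound 3 to compound 4 (beyond the scatter), although the counted heavy atoms are the same. In this assay, the two amides that keep the hydrogen also outdo the ring, with a number 17 percentage points lower from compound 1 to compound 4 (beyond the scatter) and a number 17 percentage points lower from compound 2 to compound 4 (beyond the scatter). Nothing measured here gives a reason for this drop.

As far as these compounds go, whether the fall belongs to ring closure in general or to this four-membered ring stays open. Pyrrolidin-1-yl or piperidin-1-yl on the same carbonyl carbon would separate the two.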